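The source may report more compounds than this note shows. Statements on the series, on what has been measured and on what is new or still open speak of the compounds shown alone.

Compound 2 `COc1cc(N)c(Cl)cc1NC(=O)C1CCN(CC2CCC2)CC1` shares its core with compound 1 `COc1cc(N)c(Cl)cc1NC(=O)C1CCN(CC2CC2)CC1`, differing only in the group on the saturated chain carbon bound to the amine nitrogen in the ring. In a functional assay on the whole organism for antagonist activity, with Mus musculus as the target (on this read-out lower numbers stand for an effect already at smaller amounts and higher numbers for an effect only at larger amounts of compound), compound 1 gives only a limit, > 10 mg/kg. In this assay compound 2 likewise gives only a limit, > 10 mg/kg. The step that the two limits leave unreadable from compound 1 to compound 2 therefore cannot be read; both values sit at the limit of > 10 mg/kg in this assay, at which 2 of the 2 values shown sit. Compound 3 `CCOc1ccc(CN2CCC(C(=O)Nc3cc(Cl)c(N)cc3OC)CC2)cc1` arises through (4-ethoxyphenyl in place of cyclobutyl on a saturated chain carbon bound to an amine nitrogen in a ring). No readable measured step bears on this change, so the expected step of a number no higher from compound 2 to compound 3 (the limit leaves the size open) rests on no measured guide. Compound 3 is estimated at 10 mg/kg, within 3 mg/kg to 30 mg/kg.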

Compound 3, dose for half-maximal effect: 6.3 mg/kg
For compound 3 the middle estimate is 1.6-fold (0.20 log units) above the measured one, and the stated range covers the measured number.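

Within the data shown here, compound 3 is the only compound here that gives a number rather than a limit in this assay, so a group at this position can bring the read-out within measurable range: the limit of > 10 mg/kg in this assay, at which 2 of the 3 values shown sit. Replacing the cyclobutyl with 4-ethoxyphenyl gives an at least 1.5-fold lower number from compound 2 to compound 3 (0.20 log units; that floor lies within the scatter). As far as these compounds go, replacing the cyclopropyl gives an at least 1.5-fold lower number from compound 1 to compound 3 (0.20 log units; that floor lies within the scatter), and both steps are floors, so their true size remains unknown.

From the compounds shown here alone, whether the aromatic ring alone suffices or the ethoxy group is also needed remains open, and a plain phenyl would separate the two. Going by these compounds, how an amine or a carboxylic acid on that ring would read is also open.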